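A few compounds are considered here, and "the series" means these few. Any claim that something is new, unique, unknown or untested is made for them only; others in the source may bear on it.

Measured so far:
compound 1, `C=CC1=C(C(=O)NCc2ccccc2)C(c2ccc(OC)cc2)OC1`: 39500 nM
compound 2, `C=CC1=C(C(=O)NC2CCCCC2)C(c2ccc(OC)cc2)OC1`: > 100000 nM

In a functional assay on SW480 cells (Homo sapiens) for cytotoxicity, read by MTT assay, with a stated time of 24 h (a higher number here means a weaker inhibitor, a lower number a stronger inhibitor), compound 1 gives 39500 nM. For compound 2 only a limit of the assay is recorded, > 100000 nM, so compound 2 sits at the weak end of the pair without a number of its own (the limit of > 100000 nM in this assay, at which 1 of the 2 values shown sits). For the measured compounds named here, the single measured step, an at least 2.5-fold higher number from compound 1 to compound 2 (0.40 log units; beyond the scatter), concerns the same position but runs from benzyl to cyclohexyl. Compound 3, `C=CC1=C(C(=O)NCc2ccc(C)cc2)C(c2ccc(OC)cc2)OC1`, differs from compound 2 in that (4-methylbenzyl in place of cyclohexyl on an amide-type nitrogen). This largely reverses the measured change, bringing back an aromatic six-membered ring on the amide-type nitrogen with a methyl added, so the reverse of the at least modest measured step is the guide here. Compound 3 is therefore expected to show an at least 2.5-fold lower number from compound 2 to compound 3 (0.39 log units; beyond the scatter). The estimate for compound 3 in this assay is 40000 nM, with a range from 12000 nM to 100000 nM, and a limit rather than a number remains possible.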

Compound 3, half-maximal inhibitory concentration: 31700 nM
Compound 3: the middle estimate sits 1.3-fold (0.10 log units) above what was measured; measured number inside the range.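

Going from cyclohexyl to 4-methylbenzyl on the amide-type nitrogen gives an at least 3.1-fold lower number from compound 2 to compound 3 (0.49 log units; beyond the scatter) in this assay, so the step seen with benzyl also appears with a second aromatic group. Methyl in place of hydrogen on an aromatic carbon gives a 1.2-fold lower number from compound 1 to compound 3 (0.10 log units; within the scatter) between the two benzyl-type compounds, so this methyl adds no readable change and the difference from cyclohexyl holds for both benzyl-type groups. Compound 2 remains a limit of the assay, not a number, so the step to compound 3 has no upper end: the limit of > 100000 nM in this assay, at which 1 of the 3 values shown sits.

As far as these compounds go, whether a longer chain such as 2-phenylethyl keeps this level on the amide-type nitrogen remains open. So does the response of the aromatic ring to a group other than methyl, such as a 4-chloro, 4-methoxy or carboxylic acid substituent.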